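Sulfonamide series: naphthyl replacement on compound 2

A few compounds are considered here, and "the series" means these few. Any claim that something is new, unique, unknown or untested is made for them only; others in the source may bear on it.

Measured in an assay on HEK293 cells for displacement of a labelled ligand from 5-hydroxytryptamine receptor 6 (Homo sapiens), read by radioligand binding, with a stated time of 60 min, tested at 100 nM; on this read-out higher numbers stand for more inhibition at the one concentration tested (going by the name of the read-out) and lower numbers for less inhibition:
compound 1 `CN(C)CCn1c(=O)sc2cc(S(=O)(=O)c3ccccc3)ccc21`: 16%
compound 2 `CN(C)CCn1c(=O)sc2cc(S(=O)(=O)N(C)c3ccccc3)ccc21`: 5%
compound 3 `CN(c1ccccc1)S(=O)(=O)c1ccc2c(c1)sc(=O)n2CCN1CCCC1`: 10%

Compound 2 holds the lowest of the three numbers. Compound 3 sits within the scatter of it, whereas compound 1 is clearly higher: the step is a number 11 percentage points lower from compound 1 to compound 2 (beyond the scatter), and the amine swap gives a number 5 percentage points higher from compound 2 to compound 3 (within the scatter). Compound 4 `CN(C)CCn1c(=O)sc2cc(S(=O)(=O)N(C)c3cccc4ccccc34)ccc21` differs from compound 2 in one place: naphthalen-1-yl in place of phenyl on a sulfonamide nitrogen. Going by the values given here, no measured step changes the group on the sulfonamide nitrogen; the nearest comparison is the change at the sulfonyl sulfur, which moved the read-out only modestly, and the amine change stayed within scatter. A step of a number 5 percentage points higher from compound 2 to compound 4 (within the scatter) is therefore expected, a small rise at most and none beyond the scatter. Compound 4 is estimated at 10%, range 0% to 30%.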

Compound 4, a percentage reported as inhibition, at one concentration (the size of the read-out at that concentration, not a potency): 0%
Compound 4: middle estimate off by 10 percentage points, on the high side, within the range that was stated.
By their numbers in this assay, from the lowest: compounds 4, 2, 3 and 1 (each within the scatter of the next, the first and the last beyond it).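

Going by these compounds alone, the step from phenyl to naphthalen-1-yl is the first one read at this place on the sulfonamide nitrogen, and it reads a number 5 percentage points lower from compound 2 to compound 4 (within the scatter). In this assay, going from one six-membered aromatic ring to two therefore gives no change that can be told from the scatter, and both compounds stay near the bottom of the series. Nothing available bears on the reason for this result.

On these data alone, it remains open whether pyridin-3-yl or benzyl on the sulfonamide nitrogen would give a step beyond the scatter from compound 2. Also open, as far as these compounds go, is how naphthalen-1-yl behaves with pyrrolidin-1-yl on the chain.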